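A few compounds are considered here, and "the series" means these few. Any claim that something is new, unique, unknown or untested is made for them only; others in the source may bear on it.

Measured so far in a functional assay on M21 cells (Homo sapiens) for antiproliferative activity, read by sulforhodamine B assay, with a stated time of 48 h; on this read-out lower numbers stand for stronger inhibition and higher numbers for weaker inhibition:
compound 1 `CCC(=O)Nc1ccc(S(=O)(=O)Oc2ccccc2C(C)C)cc1` – 11000 nM
compound 2 `CCC(=O)Nc1ccc(S(=O)(=O)Oc2ccccc2I)cc1` – 11000 nM
compound 3 `CC(C)C(=O)Nc1ccc(S(=O)(=O)Oc2ccccc2I)cc1` – 13000 nM

Compound 1 stands level with compound 2 at the digits shown, and its gap to compound 3 is within the scatter. The two steps seen in this assay are no change at the digits printed from compound 1 to compound 2 (within the scatter) and a 1.2-fold higher number from compound 2 to compound 3 (0.07 log units; within the scatter); neither moved the read-out beyond the scatter.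

Compound 4 `CC(C)c1ccccc1OS(=O)(=O)c1ccc(NC(=O)CCCl)cc1` differs from compound 1 by chloro in place of hydrogen on a saturated chain carbon, two bonds along the chain from a carbonyl carbon. Among the measured compounds shown here, no measured step touches this position of the chain, so nothing directly bears on the change; the steps that exist, both within the scatter, give no ground to expect a move in this assay. The expected step is therefore a 1.1-fold lower number from compound 1 to compound 4 (0.04 log units; within the scatter). Compound 4 is estimated at 10000 nM, with a range of 4000 nM to 25000 nM.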

Compound 4, half-maximal inhibitory concentration: 14000 nM
The estimate for compound 4 lay 1.4-fold (0.15 log units) below the measured number; the range from low to high includes it.
By their numbers in this assay, from the lowest: compounds 1, 2, 3 and 4 (each within the scatter of the next).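

In this assay the step of a 1.3-fold higher number from compound 1 to compound 4 (0.10 log units; within the scatter) comes with chloro in place of hydrogen on a saturated chain carbon, two bonds along the chain from a carbonyl carbon. Among the compounds shown here, this is the first reading at this position, and the change from propanoyl to (2-chloroethyl)carbonyl does not move the number beyond the scatter. No supporting data on hand account for the result.

From the compounds shown here alone, whether an amine or a carboxylic acid on this carbon, or a longer chain, would move the number beyond the scatter remains open. Every step shown so far stays within the scatter, so no group yet marks a change that matters in this series.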